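Swapping propoxy for dimethylamino on a carbonyl carbon

The source may hold more compounds than are shown below. What is called first, only, known or untested is meant among the compounds shown, and "the series" means these compounds.

In an ADME assay on HeLa cells (Homo sapiens) for cytotoxicity, read by MTT assay, with a stated time of 2 days (a higher number here means that more compound is tolerated, a lower number that less compound is tolerated), compound 1 `CNC(=O)c1cc(Oc2ccc3cc(C(=O)OC)sc3c2)ccn1` gives 68300 nM as its measured value. Compound 2 `CCCOC(=O)c1sc2cc(Oc3ccnc(C(=O)NC)c3)ccc2c1C` gives 57100 nM in the same test. These two numbers lie within the usual scatter of repeated measurements, so compound 2 stands level with compound 1, and they are the only reference points so far.

Compound 3 `CNC(=O)c1cc(Oc2ccc3c(C)c(C(=O)N(C)C)sc3c2)ccn1` has not yet been measured. It comes from compound 2 by a single change, dimethylamino in place of propoxy on a carbonyl carbon, and dimethylamino in place of propoxy on a carbonyl carbon gives the full count. Within the data shown here, no measured pair differs in just one place, so no single change can serve as a direct guide. Compound 1 at 68300 nM and compound 2 at 57100 nM differ in more than one place yet stay within the scatter of each other, so no shift beyond the scatter is expected in this assay for this swap. The estimated change is a 1.1-fold higher number from compound 2 to compound 3 (0.02 log units; within the scatter) and points in neither direction with any confidence. Compound 3 is expected to give 60000 nM with an estimated range from 25000 nM to 140000 nM when tested.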

Compound 3, half-maximal cytotoxic concentration: 44400 nM
Estimate against measurement, compound 3: 1.4-fold (0.13 log units) above; the measured number falls inside the stated range.
By their numbers in this assay, from the lowest: compounds 3, 2 and 1 (each within the scatter of the next).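

In this assay, placing dimethylamino in place of propoxy on a carbonyl carbon, which turns propoxycarbonyl into dimethylcarbamoyl, gives a 1.3-fold lower number from compound 2 to compound 3 (0.11 log units; within the scatter). Among these compounds, this is the first comparison here in which only one place differs, and it shows that this position takes either group without a shift that can be told apart from the ordinary spread of repeated measurements. No measurement shown here offers an explanation for this result or ties it to any property of the two groups.

Going by these compounds, this is a single pair, so it remains open whether the same swap would stay within the scatter on a different core. On these data alone, it also remains open whether other groups on this carbonyl carbon, such as a hydroxyl giving a carboxylic acid or a larger amine such as diethylamino, would move the number beyond the scatter in this assay.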